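A few compounds are considered here, and "the series" means these few. Any claim that something is new, unique, unknown or untested is made for them only; others in the source may bear on it.

Working notes on the benzylsulfanyl series.

Of the compounds shown here, three of the shared core have been measured in a functional assay on MCF7 cells (Homo sapiens) for cytotoxicity, read by MTT assay, with a stated time of 72 h; on this read-out lower numbers stand for stronger inhibition and higher numbers for weaker inhibition. Compound 1 `Cc1cc(S(=O)(=O)/N=C(\N)n2nccc2-c2ccccc2)c(SCc2ccccc2)cc1Cl` gives 20000 nM. Compound 2 `Cc1ccc(CSc2cc(Cl)c(C)cc2S(=O)(=O)/N=C(\N)n2nccc2-c2ccccc2)cc1` gives 21000 nM. Compound 3 `Cc1cc(S(=O)(=O)/N=C(\N)n2nccc2-c2ccccc2)c(SCc2ccccc2Cl)cc1Cl` gives 24000 nM. Compound 3 carries the highest of the three numbers, but it is separated from the others only by steps that fall within the scatter: the step from compound 1 to compound 3 was a 1.2-fold higher number from compound 1 to compound 3 (0.08 log units; within the scatter), the step from compound 2 to compound 3 was a 1.1-fold higher number from compound 2 to compound 3 (0.06 log units; within the scatter), and the step from compound 1 to compound 2 was a 1.1-fold higher number from compound 1 to compound 2 (0.02 log units; within the scatter). All three sit together in this assay.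

The next compound, compound 4 `Cc1cc(S(=O)(=O)/N=C(\N)n2nccc2-c2ccccc2)c(SCc2ccccc2C(F)(F)F)cc1Cl`, differs from compound 3 by trifluoromethyl in place of chloro on an aromatic carbon. The measured steps that bear on this are those in which the benzyl ring is changed: the step from compound 1 to compound 3 and the step from compound 2 to compound 3, both within the scatter. Nothing in the series shows that substitution on this ring moves the read-out. The expected step from compound 3 to compound 4 in this assay is therefore no change at the digits printed from compound 3 to compound 4 (within the scatter), no change beyond the scatter. Compound 4 is estimated at 24000 nM, with a range from 11000 nM to 52000 nM.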

Compound 4, half-maximal inhibitory concentration: 21000 nM
Estimate against measurement, compound 4: 1.1-fold (0.06 log units) above; measured number inside the range.
By their numbers in this assay, from the lowest: compounds 1, 2, 4 and 3 (each within the scatter of the next).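

At this position, on an aromatic carbon ortho to a large group, 4 heavy atoms enter where 1 heavy atom leaves, and the exchange of chloro for trifluoromethyl gives a 1.1-fold lower number from compound 3 to compound 4 (0.06 log units; within the scatter) in this assay. The earlier compounds shown here showed only chloro and hydrogen at this place; the new compound adds a larger group, and its steps to the other two, a 1.1-fold higher number from compound 1 to compound 4 (0.02 log units; within the scatter) and no change at the digits printed from compound 2 to compound 4 (within the scatter), leave all four compounds together, so hydrogen, chloro and trifluoromethyl at this place cannot be told apart on this read-out. No measurement at hand bears on why these compounds sit together.

Still open, from the compounds shown here alone, is whether any group on this ring can move the number beyond the scatter, since an amine or a carboxylic acid at the same place would put a hydrogen-bond donor or acceptor where chloro and trifluoromethyl have none. Also open, going by these compounds, is whether a longer chain in place of the saturated chain carbon bound to a sulfur would leave the read-out where these four compounds sit.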